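This account rests on a few compounds, and the source may have more. Where it says the series, first, only, none or still open, it means among the compounds named here.

Measured so far in a functional assay on HeLa S3 cells (Homo sapiens) for antiproliferative activity, read by XTT assay, with a stated time of 72 h; on this read-out lower numbers stand for stronger inhibition and higher numbers for weaker inhibition:
compound 1 `Cc1ncnc2c1c(-c1cccs1)cn2[C@@H]1O[C@H](CO)[C@@H](O)[C@H]1O` gives > 15000 nM, a limit of the assay
compound 2 `COc1ncnc2c1c(-c1cccs1)cn2[C@@H]1O[C@H](CO)[C@@H](O)[C@H]1O` gives 1760 nM
compound 3 `CNc1ncnc2c1c(-c1ccsc1)cn2[C@@H]1O[C@H](CO)[C@@H](O)[C@H]1O` gives > 20000 nM, a limit of the assay

Within the data shown here, only one step between compounds differing in a single place is available: an at least 8.5-fold lower number from compound 1 to compound 2 (0.93 log units; beyond the scatter), methoxy in place of methyl on an aromatic carbon. Compound 3 stands at a limit, the one set out as the limit of > 20000 nM in this assay, at which 1 of the 3 values shown sits, so on the numbers shown it sits at the weak end without a number of its own. Compound 1 likewise rests at a limit, (the limit of > 15000 nM in this assay, at which 1 of the 3 values shown sits).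

Compound 4 `CNc1ncnc2c1c(-c1cccs1)cn2[C@@H]1O[C@H](CO)[C@@H](O)[C@H]1O` differs from compound 3 by thiophen-2-yl in place of thiophen-3-yl on an aromatic carbon. Among the measured compounds shown here, no measured step covers this change; the one measured step concerns the methoxy and methyl groups at a different place and does not bear on it directly. Compound 2 carries thiophen-2-yl and gives 1760 nM, a number rather than a limit. Compound 1 also carries thiophen-2-yl and gives > 15000 nM, a limit.

With compound 3 at a limit, the expected change is an at least 3.3-fold lower number from compound 3 to compound 4 (0.52 log units; beyond the scatter), a move towards a lower number, at most modest in size. Compound 4 is therefore estimated near 6000 nM, within 1500 nM to 25000 nM, with a real chance that only a limit is reported.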

Compound 4, half-maximal inhibitory concentration: > 20000 nM
Compound 4 was reported as a limit (the forecaster's own chance of this, stated with the estimate: 40%); at least 3.3-fold (0.52 log units) between middle value and limit.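

In this assay compound 4 gives > 20000 nM, a limit of the assay, so both compounds shown with methylamino on the core rest at a limit, whichever thiophene they carry: the limit of > 20000 nM in this assay, at which 2 of the 4 values shown sit. With thiophen-2-yl held fixed, the group on the core now has a readable effect, since methylamino in place of methoxy gives an at least 11-fold higher number from compound 2 to compound 4 (1.05 log units; beyond the scatter), and among the three thiophen-2-yl compounds only compound 2, the methoxy one, has a number rather than a limit. The steps from compound 3 to compound 4 and from compound 1 to compound 4 cannot be read, as both ends of each are limits, so the exchange of thiophen-3-yl for thiophen-2-yl on this aromatic carbon has no measurable size here.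

From the compounds shown here alone, whether that exchange matters at all remains open, as it could only be read on a pair in which both partners give numbers, such as a methoxy compound carrying thiophen-3-yl beside compound 2. Going by these compounds, it is also open whether methoxy is special on the core or whether a longer chain such as ethoxy, or a dimethylamino group, would also give a number in this assay.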